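Pyridyl for Chlorophenyl: What to Expect for Solubility

The source may report more compounds than this note shows. Statements on the series, on what has been measured and on what is new or still open speak of the compounds shown alone.

Compound 1 `CCOC(=O)C1=C(O)/C(=C\c2cc(C)n(-c3ccc(F)cc3)c2C)N=C1C`: 3.1 ug/mL in a physicochemical assay for solubility, read by nephelometry, in phosphate buffer, measured as kinetic solubility, at pH 6.5; on this read-out higher numbers stand for higher solubility and lower numbers for lower solubility
Compound 2 `CCOC(=O)C1=C(C)N/C(=C/c2cc(C)n(-c3ccc(Cl)cc3)c2C)C1=O`: 1.6 ug/mL
Compound 3 `CCOC(=O)C1=C(C)N/C(=C/c2cc(C)n(-c3cccc(OC)c3)c2C)C1=O`: < 1.6 ug/mL, which is a limit of the assay

Among the two numbers shown, compound 2 and compound 1 sit within the usual scatter of each other, so no order between them can be read. Compound 4 `CCOC(=O)C1=C(C)N/C(=C/c2cc(C)n(-c3cccnc3)c2C)C1=O` differs from compound 2 by pyridin-3-yl in place of 4-chlorophenyl on an aromatic nitrogen. For the measured compounds named here, the one measured step that bears on this, a number no higher from compound 2 to compound 3 (the limit leaves the size open), also exchanges the aryl group on that nitrogen, but its size cannot be read because of the limit of < 1.6 ug/mL in this assay, at which 1 of the 3 values shown sits. With no readable step to lean on, the change is expected to leave solubility roughly where compound 2 stands. Compound 4 is therefore estimated at about 3 ug/mL, within a range of 1.5 ug/mL to 8 ug/mL. This corresponds to an expected step of a 1.9-fold higher number from compound 2 to compound 4 (0.27 log units; within the scatter).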

Compound 4, solubility: 25 ug/mL
Beside the measured number, compound 4's estimate is 8.3-fold (0.92 log units) below it, and the stated range ends below it.
By their numbers in this assay, from the lowest: compounds 2 and 1 (each within the scatter of the next); then compound 4.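

The earlier compounds shown here gave no readable step on this aromatic nitrogen, but in this assay pyridin-3-yl in place of 4-chlorophenyl now gives a 16-fold higher number from compound 2 to compound 4 (1.19 log units; beyond the scatter). Pyridin-3-yl in place of 3-methoxyphenyl gives an at least 15-fold higher number from compound 3 to compound 4 (1.19 log units; beyond the scatter). That second step starts from a limit for compound 3, and only its minimum size can be read: the limit of < 1.6 ug/mL in this assay, at which 1 of the 4 values shown sits.

Pyridin-3-yl is the only ring shown here with a hetero atom. As far as these compounds go, whether pyridin-4-yl, or a phenyl ring carrying a carboxylic acid or an amine, would give a similar step remains open.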